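A few compounds are considered here, and "the series" means these few. Any claim that something is new, unique, unknown or untested is made for them only; others in the source may bear on it.

Measured in a functional assay (aorta) for inhibition, with Rattus norvegicus as the target; a higher number here means a weaker inhibitor, a lower number a stronger inhibitor:
Compound 1 `C/N=C(\S)[C@]1(c2ccncc2)CCCC[S+]1[O-]`: 25000 nM
Compound 2 `C/N=C(\S)[C@]1(c2cccc(C(F)(F)F)c2)CCCC[S+]1[O-]`: 800 nM
Compound 3 `CCC/N=C(\S)[C@]1(c2cccnc2)CCCC[S+]1[O-]`: 600 nM

Compound 3, at 600 nM, lies within the scatter of compound 2, at 800 nM, so the two cannot be ranked. Compound 1, at 25000 nM, has a number well beyond the scatter from compound 3, which marks it as the clearly weaker inhibitor of that pair.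

The next compound to be tested in this assay is compound 4 `COC(=N)[C@]1(c2cccnc2)CCCC[S+]1[O-]`. It differs from compound 3 by one change: a group of 4 heavy atoms (2 carbon, 1 nitrogen, 1 oxygen; no ring) in place of a group of 6 heavy atoms (4 carbon, 1 nitrogen, 1 sulfur; no ring), on a saturated ring carbon. This change lies on a saturated ring carbon, next to the ring sulfur. Going by the values given here, no pair of measured compounds differs in one place only, so the data give no direct precedent for the size of this step. All three measured compounds carry a sulfur-bearing group at this carbon, and compound 4 does not, so it moves outside the measured set. The values do show a wide span, with compound 1 at 25000 nM. A loss of potency beyond the scatter is therefore expected, though its size is uncertain.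

The expected change is a 13-fold higher number from compound 3 to compound 4 (1.12 log units; beyond the scatter). For compound 4 the estimated value is 8000 nM, with an expected range from 1500 nM to 40000 nM.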

Compound 4, concentration for 90% inhibition: > 30000 nM
Compound 4: only a limit was reported; the forecaster's own chance of this, stated with the estimate: 15%; middle value at least 3.7-fold (0.57 log units) from the limit.
By their numbers in this assay, from the lowest: compounds 3 and 2 (each within the scatter of the next); then compound 1. At a limit, above all of these: compound 4.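

In this assay, going by these compounds alone, the only step between compounds that differ in one place is an at least 50-fold higher number from compound 3 to compound 4 (1.69 log units; beyond the scatter), and it is beyond the scatter. It shows that the saturated ring carbon next to the ring sulfur is sensitive to the group it carries: with the core and the pyridine-bearing part of compound 3 kept, replacing the group of 6 heavy atoms, which holds sulfur, by the group of 4 heavy atoms, which holds oxygen, costs a large part of the potency. The reading for compound 4 is a limit and not a number, so the full size of this loss stays unknown: the limit of > 30000 nM in this assay, at which 1 of the 4 values shown sits.

The step changes the size of the group and swaps sulfur for oxygen at the same time, so the compounds shown do not tell which of the two matters, and an amide carrying the same chain as compound 3 would separate them. They also leave open how other groups at this carbon would behave, such as a carboxylic acid, an amine or a longer chain on the nitrogen.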